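The compounds below may be only part of what the source reports. "The series", "measured", "known", "first", "only" and "open" are said of these compounds alone.

Working notes on the series. The three measured compounds share one core. Compound 1 `COc1cc(/C=C/C(=O)/C=C(O)/C=C/c2ccc(O[C@H]3C[C@H]([C@@H](C)CCC=C(C)C)[C@@H](O)C=C3C)c(OC)c2)ccc1O` gives 64100 nM in a functional assay on HepG2 cells (Homo sapiens) for cytotoxicity, read by crystal violet staining, with a stated time of 72 h; a lower number here means a stronger inhibitor, a higher number a weaker inhibitor. Compound 2 `COc1cc(/C=C/C(=O)/C=C(O)/C=C/c2ccc(O[C@H]3C[C@H]([C@@H](C)CC(=O)C=C(C)C)C=C[C@@]3(C)O)c(OC)c2)ccc1O` gives 18300 nM in this assay. Compound 3 `COc1cc(/C=C/C(=O)/C=C(O)/C=C/c2ccc(O[C@]3(C)C=C[C@@H]([C@@H](C)CCC=C(C)C)C[C@@H]3O)c(OC)c2)ccc1O` gives 35900 nM in this assay, the second highest of the three numbers; its gap to compound 1 and its gap to compound 2 both lie within the scatter, so no order among the three can be read.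

Compound 4 `COc1cc(/C=C/C(=O)/C=C(O)/C=C/c2ccc(O[C@]3(C)C=C[C@@H]([C@@H](C)CC(=O)C=C(C)C)C[C@@H]3O)c(OC)c2)ccc1O` is not yet measured. It differs from compound 3 by (2-methylprop-1-en-1-yl)carbonyl in place of 3-methylbut-2-en-1-yl on a saturated chain carbon, two bonds along the chain from a saturated ring carbon. Within the data shown here, no measured pair shows this change alone. Compound 2, which also carries the (2-methylprop-1-en-1-yl)carbonyl, gives the lowest number, but it differs from the others in more than one place. A small lowering is expected for compound 4, a 1.5-fold lower number from compound 3 to compound 4 (0.17 log units; within the scatter), likely within the scatter. Compound 4 is estimated at 24000 nM, between 9000 nM and 60000 nM.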

Compound 4, half-maximal inhibitory concentration: 15700 nM
Beside the measured number, compound 4's estimate is 1.5-fold (0.18 log units) above it; the range from low to high includes it.
By their numbers in this assay, from the lowest: compounds 4, 2, 3 and 1 (each within the scatter of the next, the first and the last beyond it).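

The swap of 3-methylbut-2-en-1-yl for (2-methylprop-1-en-1-yl)carbonyl on a saturated chain carbon, two bonds along the chain from a saturated ring carbon, can now be read alone. In this assay, among these compounds, it gives a 2.3-fold lower number from compound 3 to compound 4 (0.36 log units; beyond the scatter) as a modest step, the first single-place change and one that lies beyond the scatter. Nothing measured here accounts for this step.

This one pair leaves open whether the step carries over to the core of compound 1. It also leaves open how an amine, a carboxylic acid or a longer chain would read at this position.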